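The source may report more compounds than this note shows. Statements on the series, on what has been measured and on what is new or still open speak of the compounds shown alone.

Compound 3 `CCc1ccc(NC(=O)c2cccc(/C=C3\CC(=O)N(c4ccccc4)C3=O)c2)cc1` reaches only a limit in an ADME assay on SW480 cells (Homo sapiens) for cytotoxicity, read by MTT assay, with a stated time of 72 h; on this read-out higher numbers stand for weaker inhibition and lower numbers for stronger inhibition: compound 3 gives > 100000 nM, which is a limit of the assay and not a number. Compound 1 `CSc1cccc(NC(=O)c2cccc(/C=C3\CC(=O)N(c4ccccc4)C3=O)c2)c1` gives 74300 nM in this assay. Compound 2 `O=C(Nc1ccc(OC(F)F)cc1)c1cccc(/C=C2\CC(=O)N(c3ccccc3)C2=O)c1` also sits at a limit in this assay, where compound 2 gives > 100000 nM. Two of the three values rest at the limit of > 100000 nM in this assay, at which 2 of the 3 values shown sit. Compound 4 `O=C(Nc1cccc(F)c1)c1cccc(/C=C2\CC(=O)N(c3ccccc3)C2=O)c1` differs from compound 3 by 3-fluorophenyl in place of 4-ethylphenyl on an amide-type nitrogen. The measured steps that bear on such a change are an at least 1.3-fold higher number from compound 1 to compound 2 (0.12 log units; that floor lies within the scatter) and an at least 1.3-fold higher number from compound 1 to compound 3 (0.12 log units; that floor lies within the scatter), while a step that the two limits leave unreadable from compound 2 to compound 3. Each change shown so far has left the number near or beyond the limit, so compound 4 is expected to stay there as well, giving an at least 1.1-fold lower number from compound 3 to compound 4 (0.04 log units; that floor lies within the scatter). The estimate for compound 4 is 90000 nM, between 45000 nM and 200000 nM.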

Compound 4, half-maximal inhibitory concentration: > 100000 nM
Compound 4: only a limit was reported; the forecaster's own chance of this, stated with the estimate: 55%; middle value at least 1.1-fold (0.04 log units) from the limit.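

In this assay, compound 4 also ends at a limit of the assay, so 3-fluorophenyl on the amide-type nitrogen gives no measurable number. Fluoro in place of methylsulfanyl gives an at least 1.3-fold higher number from compound 1 to compound 4 (0.12 log units; that floor lies within the scatter), which shows no step beyond the scatter, and the steps from compound 2 and compound 3 to compound 4 cannot be read. A fluoro directly on the ring thus adds one more case at the same limit: the limit of > 100000 nM in this assay, at which 3 of the 4 values shown sit.

From the compounds shown here alone, how an amine or a carboxylic acid on this ring would read remains open. So does whether any group at this place can bring the number far under that limit.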